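This account rests on a few compounds, and the source may have more. Where it says the series, first, only, none or still open, it means among the compounds named here.

Measured so far:
compound 1, `CCN(CC)CCNC(=O)c1ccc(C(CC)(CC)c2ccc(OCC(=O)C(C)(C)C)c(C)c2)n1CC`, 91 nM in an assay on HL-60 cells for agonist activity at vitamin D3 receptor (Homo sapiens), read by microscopy, with a stated time of 96 h; on this read-out lower numbers stand for an effect already at smaller amounts and higher numbers for an effect only at larger amounts of compound;
compound 2, `CCn1c(C(=O)NCCN(C)C)ccc1C(CC)(CC)c1ccc(OCC(=O)C(C)(C)C)c(C)c1`, 77 nM in this assay;
compound 3, `CCn1c(C(=O)NCCCN(C)C)ccc1C(CC)(CC)c1ccc(OCC(=O)C(C)(C)C)c(C)c1`, 96 nM in this assay.

The three compounds share one core and differ only in the basic amine at the end of the amide side chain. Compound 3 differs from compound 2 by (dimethylamino)methyl in place of dimethylamino on a saturated chain carbon, two bonds along the chain from an amide-type nitrogen, and that step reads a 1.2-fold higher number from compound 2 to compound 3 (0.10 log units; within the scatter). Compound 4, `CCN(CC)CCCNC(=O)c1ccc(C(CC)(CC)c2ccc(OCC(=O)C(C)(C)C)c(C)c2)n1CC`, has not yet been measured; it differs from compound 3 by diethylamino in place of dimethylamino on a saturated chain carbon, three bonds along the chain from an amide-type nitrogen. The same kind of change, though not the same one, is seen between compound 2 and compound 1: there it is diethylamino in place of dimethylamino on a saturated chain carbon, two bonds along the chain from an amide-type nitrogen, two bonds along the chain rather than three, and it gave a 1.2-fold higher number from compound 2 to compound 1 (0.07 log units; within the scatter). Because a 1.2-fold higher number from compound 2 to compound 1 (0.07 log units; within the scatter) stayed within the scatter, the step from compound 3 to compound 4 is expected to be small as well, about a 1.1-fold higher number from compound 3 to compound 4 (0.06 log units; within the scatter). Compound 4 is therefore estimated at 110 nM in this assay, with a likely range from 55 nM to 220 nM.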

Compound 4, half-maximal effective concentration: 22 nM
The estimate for compound 4 lay 5.0-fold (0.70 log units) above the measured number; the whole stated range lies above it.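

In this assay, the swap of dimethylamino for diethylamino did not carry over from the 2-(dimethylamino)ethyl chain to the 3-(dimethylamino)propyl chain, and the two steps clearly differ: the same change on two cores in this assay, a 1.2-fold higher number (0.07 log units; within the scatter) from compound 2 to compound 1 and a 4.4-fold lower number (0.64 log units; beyond the scatter) from compound 3 to compound 4, 5.2-fold (0.71 log units) apart, beyond the scatter of two such steps. The new result is a clear drop in the number, with a 4.4-fold lower number from compound 3 to compound 4 (0.64 log units; beyond the scatter), a 3.5-fold lower number from compound 2 to compound 4 (0.54 log units; beyond the scatter) and a 4.1-fold lower number from compound 1 to compound 4 (0.62 log units; beyond the scatter). For the compounds shown here, this shows that the change cannot be assumed to behave alike on both chains, but with only one pair per chain, it does not show why the steps differ or what the change would do on another chain.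

Still open, as far as these compounds go, is whether a longer chain would keep the lower number. The same question applies to a ring amine such as piperidine or morpholine at the chain end.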